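The source may report more compounds than this note shows. Statements on the series, on what has been measured and on what is new or still open speak of the compounds shown alone.

Series notes, inhibition of cell growth.

In a functional assay on MDA-MB-231 cells (Homo sapiens) for inhibition, read by sulforhodamine B assay, with a stated time of 48 h, tested at 10 uM (on this read-out lower numbers stand for less inhibition and higher numbers for more inhibition at the one concentration tested (going by the name of the read-out)), compound 2 `COc1ccc(-c2cn3ccnc3c(-c3ccc4ncn(C5CCCCC5)c4c3)n2)cc1` gives 71.1%, the highest of the three numbers measured. Compound 1 `Brc1cn2ccnc2c(-c2ccc3ncn(C4CCCCC4)c3c2)n1` gives 24.2% in this assay and compound 3 `Clc1ccc(-c2cn3ccnc3c(-c3ccc4ncn(C5CCCCC5)c4c3)n2)cc1` gives 15.3%. The steps are a number 46.9 percentage points higher from compound 1 to compound 2 (beyond the scatter) and a number 55.8 percentage points lower from compound 2 to compound 3 (beyond the scatter), both beyond the scatter, while a number 8.9 percentage points lower from compound 1 to compound 3 (within the scatter) stays within it.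

Compound 4 `Fc1ccccc1-c1cn2ccnc2c(-c2ccc3ncn(C4CCCCC4)c3c2)n1` is to be measured next. Against compound 2 the change is 2-fluorophenyl in place of 4-methoxyphenyl on an aromatic carbon.

For the measured compounds named here, the step that bears most directly on this is the one from compound 2 to compound 3, where a number 55.8 percentage points lower from compound 2 to compound 3 (beyond the scatter) followed when chloro replaced methoxy on an aromatic carbon: removing the methoxy group for a halogen cost most of the inhibition. Compound 4 also loses the methoxy and carries a halogen, though fluoro rather than chloro and on a different ring position. A drop beyond the scatter is therefore expected, though perhaps not the full size seen for compound 3; the expected step is a number 43.1 percentage points lower from compound 2 to compound 4 (beyond the scatter). Compound 4 is estimated at 28%, with a range from 8% to 55%.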

Compound 4, a percentage reported as inhibition, at one concentration (the size of the read-out at that concentration, not a potency): 21.3%
Estimate against measurement, compound 4: 6.7 percentage points above; measured number inside the range.
By their numbers in this assay, from the lowest: compounds 3, 4 and 1 (each within the scatter of the next); then compound 2.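

Replacing 4-methoxyphenyl with 2-fluorophenyl gives (a number 49.8 percentage points lower from compound 2 to compound 4 (beyond the scatter)) in this assay, so the fall seen with chloro also appears with a different halogen at a different place on the phenyl ring. Compound 4 is not separated from the 4-chlorophenyl compound (a number 6 percentage points higher from compound 3 to compound 4 (within the scatter)) or from the bromo compound (a number 2.9 percentage points lower from compound 1 to compound 4 (within the scatter)), so among these four compounds only the 4-methoxyphenyl group stands apart, and a phenyl ring at this position does not by itself raise the number above that of bromo. No measurement here accounts for this difference.

The compounds shown do not separate the contribution of the methoxy group from that of its place on the phenyl ring. From the compounds shown here alone, whether a hydroxyl group or an amine on that ring would match compound 2 also remains open.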